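The compounds below may be only part of what the source reports. "The series", "measured", "known", "first", "only" and "open" are said of these compounds alone.

Three compounds have been run through an ADME assay on liver for metabolic stability, with Liver microsome (Homo sapiens) as the target, read by LC-MS, using microsomes, with a stated time of 5 h; on this read-out higher numbers stand for fast clearance and lower numbers for slow clearance. Compound 1, with structure `OC(c1ccccn1)C1(c2ccc(Cl)c(Cl)c2)CCOC1`, gives 417 mL/min/kg in this assay. Compound 2, with structure `C[C@@]1(c2ccc(OC(F)(F)F)cc2)C[C@](O)(c2ccccn2)CO1`, gives 217 mL/min/kg in this assay. Compound 3, with structure `OC(c1ccc(F)cn1)C1(c2ccc(Cl)c(Cl)c2)CCC1`, gives 767 mL/min/kg in this assay. Within the data shown here, of the three numbers, the one for compound 3 sits at the top, yet its gap to compound 1 lies within the usual scatter of repeated measurements, so those two cannot be told apart; only its gap to compound 2 lies beyond the scatter.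

Compound 4, with structure `OC(c1cc(F)ccn1)C1(c2ccc(Cl)c(Cl)c2)CCC1`, has not yet been measured. It differs from compound 3 in a single place: 4-fluoropyridin-2-yl in place of 5-fluoropyridin-2-yl on a saturated chain carbon bound to an oxygen on a saturated carbon and a saturated ring carbon. Among the measured compounds shown here, no measured pair shows this kind of change, so there is no step to draw on. With the same atoms simply joined differently, the expectation is a step of no size beyond the scatter, a 1.2-fold lower number from compound 3 to compound 4 (0.07 log units; within the scatter), with no clear direction. Compound 4 is therefore estimated at 650 mL/min/kg in this assay, within a range from 300 mL/min/kg to 1400 mL/min/kg.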

Compound 4, clearance: 533 mL/min/kg
For compound 4 the middle estimate is 1.2-fold (0.09 log units) above the measured one; the range from low to high includes it.
By their numbers in this assay, from the lowest: compounds 2, 1, 4 and 3 (each within the scatter of the next, the first and the last beyond it).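

In this assay, putting 4-fluoropyridin-2-yl in place of 5-fluoropyridin-2-yl, on a saturated chain carbon bound to an oxygen on a saturated carbon and a saturated ring carbon, gives a 1.4-fold lower number from compound 3 to compound 4 (0.16 log units; within the scatter). Among these compounds, this is the first pair in the set that differs in one place, and it shows that these two placements of the fluorine cannot be told apart on this read-out, so compound 3 and compound 4 count as equal here. No measurement at hand offers an explanation for the size of this step.

Going by these compounds, it remains open whether a nitrile or an amine in place of the fluorine would move the number beyond the scatter. Also open, on these data alone, is whether the same exchange on the core of compound 1 would give a step of similar size.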